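The source may hold more compounds than are shown below. What is called first, only, known or untested is meant among the compounds shown, and "the series" means these compounds.

Compound 3 `CCC(=O)Nc1cc(C(=O)Nc2nccs2)ccc1OC` stands at the upper edge of a small set of three related amides tested in an ADME assay on MDCK cells (Canis lupus familiaris) for cytotoxicity, read by cytopathic effect, with a stated time of 48 h; on this read-out higher numbers stand for lower toxicity in this test and lower numbers for higher toxicity in this test. Its own result is a limit of the assay, > 655 uM. Compound 1 `CCC(=O)Nc1cc(C(=O)NC2CCCCC2)ccc1OC` gives 510 uM. For compound 2 `CCC(=O)Nc1cc(C(=O)NC2CCC2)ccc1OC` the result is likewise a limit, > 724 uM. The measured steps are all small: an at least 1.2-fold higher number from compound 1 to compound 3 (0.10 log units; that floor lies within the scatter), and a step that the two limits leave unreadable from compound 2 to compound 3; for comparison, an at least 1.4-fold higher number from compound 1 to compound 2 (0.15 log units; that floor lies within the scatter). Compound 4 `CCC(=O)Nc1cc(C(=O)Oc2ccccc2)ccc1OC` differs from compound 3 by phenoxy in place of (1,3-thiazol-2-yl)amino on a carbonyl carbon. For the measured compounds named here, none of the measured steps reaches beyond the scatter, and the limit of > 655 uM in this assay, at which 1 of the 3 values shown sits, caps what can be read, so the expected step is an at least 1.0-fold lower number from compound 3 to compound 4 (0.03 log units; that floor lies within the scatter), nothing beyond the scatter. Compound 4 is therefore estimated at 600 uM, within 250 uM to 900 uM.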

Compound 4, half-maximal toxic concentration: 464 uM
Compound 4: the middle estimate sits 1.3-fold (0.11 log units) above what was measured; low and high end bracket the measured number.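

In this assay, phenoxy on a carbonyl carbon is the first group shown at this place without a hydrogen-bond donor, yet no step passes the scatter: a 1.1-fold lower number from compound 1 to compound 4 (0.04 log units; within the scatter), an at least 1.5-fold lower number from compound 2 to compound 4 (0.19 log units; that floor lies within the scatter) and an at least 1.4-fold lower number from compound 3 to compound 4 (0.14 log units; that floor lies within the scatter). The step from compound 3 remains a floor because compound 3 stands at a limit: the limit of > 655 uM in this assay, at which 1 of the 4 values shown sits. The step from compound 2 remains a floor for the same reason, since compound 2 also stands at a limit: the limit of > 724 uM in this assay, at which 1 of the 4 values shown sits.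

The compounds shown leave open whether any group at this place moves the number beyond the scatter. A carboxylic acid or a dimethylamino group on the carbonyl carbon would test this.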